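The source may hold more compounds than are shown below. What is called first, only, known or untested is meant among the compounds shown, and "the series" means these compounds.

Measured so far in a functional assay on CHO cells for antagonist activity at sphingosine 1-phosphate receptor 2 (Homo sapiens), read by calcium flux; on this read-out lower numbers stand for stronger inhibition and higher numbers for weaker inhibition:

Compound 1, `COc1cc(OC)c(NC(=O)Cn2nc(CC(=O)O)c3ccccc32)cc1Cl`; compound 1 gives 3360 nM
Compound 2, `CCC(C(=O)O)c1nn(Cc2cn3cc(OCC4CC4)c(Cl)cc3n2)c2ccccc2c1=O`; compound 2 gives 5.6 nM
Compound 3, `COc1cc(OC)c(NC(=O)Cc2nn(CC(=O)O)c(=O)c3ccccc23)cc1Cl`; compound 3 gives 186 nM

Compound 2 holds the lowest number of the three in this assay. Its nearest neighbour is compound 3, and that gap is already beyond the scatter; the gap to compound 1 is wider still. None of the three measured compounds differs from another in a single place, so neither gap can be traced to one structural change, and the two values of each pair are all that can be said of it.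

Compound 4, `CC(C(=O)O)c1nn(Cc2cn3cc(OCC4CC4)c(Cl)cc3n2)c2ccccc2c1=O`, has not yet been measured in this assay. Set against compound 2 the difference is: hydrogen in place of methyl on a saturated chain carbon, two bonds along the chain from an aromatic carbon and a carbonyl carbon. One carbon leaves and nothing with a ring, a donor or an acceptor enters. Going by the values given here, no measured pair shows this change, so the expectation rests on compound 2 alone and on the smallness of the change. A modest rise in the number is expected, near the edge of the scatter rather than far beyond it; the estimated step is a 2.5-fold higher number from compound 2 to compound 4 (0.40 log units; beyond the scatter). Compound 4 is therefore expected at 14 nM, with a range from 4 nM to 50 nM.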

Compound 4, half-maximal inhibitory concentration: 6 nM
The estimate for compound 4 lay 2.3-fold (0.37 log units) above the measured number; low and high end bracket the measured number.
By their numbers in this assay, from the lowest: compounds 2 and 4 (each within the scatter of the next); then compound 3; then compound 1.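

Going by these compounds alone, this is the first pair that differs in one place, so it is the first reading of a single structural change. In this assay, hydrogen in place of methyl on the saturated chain carbon, two bonds along the chain from an aromatic carbon and a carbonyl carbon, gives a 1.1-fold higher number from compound 2 to compound 4 (0.03 log units; within the scatter), and the two values cannot be told apart. The change from 1-carboxypropyl to 1-carboxyethyl therefore leaves the read-out unresolved from that of the parent at this position, although this single pair says nothing about other changes there, and no supporting data are available to account for the result.

The compounds shown leave open how far this position accepts change: a carboxymethyl group, a longer chain such as propyl or butyl, a cyclopropyl ring, or a hydroxyl or an amine on the same carbon could each read differently. They also leave open whether the carboxylic acid itself can give way to a tetrazole or a primary amide, and whether the same exchange of ethyl for methyl would read the same way on the core of compound 3.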